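Swapping fluoro for methoxy on a near-inactive compound

The compounds below may be only part of what the source reports. "The series", "measured", "known", "first", "only" and "open" are said of these compounds alone.

compound 1 `Cc1ccc2[nH]c(-c3cn(-c4ccccc4)nc3-c3ccccc3)nc2c1`: 3610 nM
compound 2 `Cc1ccc2[nH]c(-c3cn(-c4ccccc4)nc3-c3ccc(F)cc3)nc2c1`: 1440 nM
compound 3 `Cc1cc2nc(-c3cn(-c4ccccc4)nc3-c3ccc(F)cc3)[nH]c2cc1C`: > 50000 nM (a limit)

In a functional assay on A549 cells (Homo sapiens) for antiproliferative activity, read by MTT assay, with a stated time of 48 h (a higher number here means a weaker inhibitor, a lower number a stronger inhibitor), compound 3 gives > 50000 nM, and this is a limit of the assay, not a number.

Compound 4 `COc1ccc(-c2nn(-c3ccccc3)cc2-c2nc3cc(C)c(C)cc3[nH]2)cc1` differs from compound 3 in one place: methoxy in place of fluoro on an aromatic carbon. Methoxy stands in place of fluoro on an aromatic carbon, para to a large group, so 4-fluorophenyl becomes 4-methoxyphenyl.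

Among the measured compounds shown here, no measured step makes this exact swap. The closest is a 2.5-fold lower number from compound 1 to compound 2 (0.40 log units; beyond the scatter), which put fluoro in place of hydrogen at this same spot, and that step was modest. The other measured step, an at least 34-fold higher number from compound 2 to compound 3 (1.54 log units; beyond the scatter), was large, and compound 4 keeps the methyl added there. A modest move toward a lower number is therefore the expectation, leaving compound 4 weak, and the assay may again report only a limit.

The expected change is an at least 1.4-fold lower number from compound 3 to compound 4 (0.15 log units; that floor lies within the scatter). Compound 4 is estimated at 35000 nM, with an expected range from 10000 nM to 80000 nM.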

Compound 4, half-maximal inhibitory concentration: 5850 nM
The estimate for compound 4 lay 6.0-fold (0.78 log units) above the measured number; the measured number lies below the stated range.
By their numbers in this assay, from the lowest: compound 2; then compounds 1 and 4 (each within the scatter of the next). At a limit, above all of these: compound 3.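

In this assay, methoxy in place of fluoro gives an at least 8.5-fold lower number from compound 3 to compound 4 (0.93 log units; beyond the scatter). Until now this position had shown only a change from hydrogen to fluoro, and this result shows that a swap here can bring a compound from a limit to a measured number. Compound 3 gives > 50000 nM, which is a limit of the assay and not a number, so the true size of the step stays unknown because one end of it is only a limit: the limit of > 50000 nM in this assay, at which 1 of the 4 values shown sits.

Going by these compounds, how an amine, a hydroxyl or a longer chain such as ethoxy would read at this position remains open. Also open, on these data alone, is whether methoxy would bring a step of this size on the core of compound 2, which carries one methyl fewer.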